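Aryl hydrazone variation at the urea hydrazone carbon

This account rests on a few compounds, and the source may have more. Where it says the series, first, only, none or still open, it means among the compounds named here.

Measured compounds in a functional assay on NCI-H460 cells (Homo sapiens) for cytotoxicity, read by MTT assay, with a stated time of 72 h; on this read-out higher numbers stand for weaker inhibition and lower numbers for stronger inhibition:
- compound 1, `CN(C)CCn1cnnc1-c1cc(Oc2ccc(NC(=O)N/N=C/c3c[nH]c4ccccc34)cc2F)ccn1`: 1630 nM
- compound 2, `CN(C)CCn1cnnc1-c1cc(Oc2ccc(NC(=O)N/N=C/c3cc(C(C)(C)C)cc(C(C)(C)C)c3O)cc2F)ccn1`: 590 nM
- compound 3, `COc1ccc(OC)c(/C=N/NC(=O)Nc2ccc(Oc3ccnc(-c4nncn4CCN(C)C)c3)c(F)c2)c1`: 2930 nM

Compound 3 gives the highest number of the three in this assay. Its nearest neighbour is compound 1, with the step of a 1.8-fold higher number from compound 1 to compound 3 (0.25 log units; within the scatter); compound 2 stands furthest away, and the gap between compound 2 and compound 3 lies beyond the scatter.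

Compound 4, `CN(C)CCn1cnnc1-c1cc(Oc2ccc(NC(=O)N/N=C/c3ccc(F)cc3)cc2F)ccn1`, is not yet measured. The change from compound 3 is 4-fluorophenyl in place of 2,5-dimethoxyphenyl on a carbon with a double bond to nitrogen. Among the measured compounds shown here, the only measured step at this place is the one from compound 1 to compound 3, and it stayed within the scatter. For the measured compounds named here, compound 2 shows that a different aryl group here can bring the number down, but no single-change step links it to compound 3. On this basis a move of moderate size at most is expected, in either direction, as a 1.5-fold lower number from compound 3 to compound 4 (0.17 log units; within the scatter). The estimate for compound 4 in this assay is 2000 nM, with a range from 700 nM to 6000 nM.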

Compound 4, half-maximal inhibitory concentration: 1980 nM
Compound 4: the middle estimate sits 1.0-fold (0.00 log units) above what was measured, within the range that was stated.
By their numbers in this assay, from the lowest: compound 2; then compounds 1, 4 and 3 (each within the scatter of the next).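

In this assay, both new steps at this carbon stay within the scatter: a 1.5-fold lower number from compound 3 to compound 4 (0.17 log units; within the scatter) and a 1.2-fold higher number from compound 1 to compound 4 (0.08 log units; within the scatter). The series now holds three aryl groups linked by single changes, and 4-fluorophenyl, which has no hydrogen-bond acceptors, cannot be told apart from either 2,5-dimethoxyphenyl, which has them, or the fused 1H-indol-3-yl; so neither the loss of the two methoxy groups nor the smaller group gives a readable change here. No supporting data bear on why these groups read alike.

Compound 2, at 590 nM, still stands alone, and the compounds shown do not separate the contribution of its hydroxyl group from that of its tert-butyl groups. Also open, going by these compounds, is how a phenyl group carrying an amine or a carboxylic acid would read at this carbon.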